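Compound 3 to compound 4: anilino replaces dimethylamino

The source may report more compounds than this note shows. Statements on the series, on what has been measured and on what is new or still open speak of the compounds shown alone.

Values measured in a functional assay on L02 cells (Homo sapiens) for inhibition, read by Griess assay, with stated times of 1 h and 24 h (a higher number here means a weaker inhibitor, a lower number a stronger inhibitor), are as follows.
- Compound 1 `CCCc1nn(C)c2c(NCc3ccc(F)cc3)nc(/C=C/c3nc(C)c(C)nc3C)nc12` gives > 1000000 nM as a limit
- Compound 2 `CCCc1nn(C)c2c(NC(C)C)nc(CCc3cccnc3)nc12` gives 514000 nM as a number
- Compound 3 `CN(C)c1nc(/C=C/c2ccccc2)nc2ccsc12` gives > 1000000 nM as a limit

Compound 3 has no numerical value in this assay and reads only > 1000000 nM as a limit. Its standing is therefore given by the limit of > 1000000 nM in this assay, at which 2 of the 3 values shown sit, and by nothing finer. Only compound 2 gives a number, at 514000 nM in the same read-out.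

The unmeasured compound 4 `C(=C/c1nc(Nc2ccccc2)c2sccc2n1)\c1ccccc1` differs from compound 3 by anilino in place of dimethylamino on an aromatic carbon in one place. The anilino group sits next to the ring nitrogen.

Among the measured compounds shown here, no measured pair shows this change, so the series gives no direct size for the step in this assay. For the measured compounds named here, a modest move towards stronger inhibition is expected, or none that can be seen, since compound 2 at 514000 nM is the only sign that a number can be reached here. Another limit reading would not be surprising.

The estimated step is an at least 1.6-fold lower number from compound 3 to compound 4 (0.22 log units; that floor lies within the scatter) and remains a rough expectation.

For compound 4 the estimate is 600000 nM as an expected value, with an expected range of 150000 nM to 2000000 nM in this assay.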

Compound 4, half-maximal inhibitory concentration: > 1000000 nM
Compound 4: no number, only a limit; the forecaster's own chance of this, stated with the estimate: 55%; middle value at least 1.6-fold (0.22 log units) from the limit.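

In this assay, compound 3 and compound 4 both read only as limits, and no step can be read for anilino in place of dimethylamino on an aromatic carbon because both compounds rest on the same limit: the limit of > 1000000 nM in this assay, at which 3 of the 4 values shown sit.

The compounds shown leave open how large this step is, and in which direction it runs.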